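Aryl sulfonamide series: working notes on growth inhibition

A few compounds are considered here, and "the series" means these few. Any claim that something is new, unique, unknown or untested is made for them only; others in the source may bear on it.

Measured so far in a functional assay on cells (leukaemia cell line, Homo sapiens) for inhibition, read by sulforhodamine B assay, with a stated time of 48 h; a lower number here means a stronger inhibitor of growth, a higher number a weaker inhibitor of growth:
Compound 1 `O=S(=O)(Nc1ccccc1Cl)c1ccc(-c2cnc(C3CC3)o2)cc1` gives 429 nM.
Compound 2 `O=S(=O)(Nc1ccc(F)c(Cl)c1)c1ccc(-c2cnc(C3CC3)o2)cc1` gives 260 nM.

Among the compounds with values here, compound 2 holds the lowest of the two numbers in this assay, but its only neighbour, compound 1, sits within the scatter of it: the step of a 1.7-fold lower number from compound 1 to compound 2 (0.22 log units; within the scatter) does not separate the two. Compound 3 `Cc1ccc(Cl)c(NS(=O)(=O)c2ccc(-c3cnc(C4CC4)o3)cc2)c1` is yet to be measured. Its change from compound 2 is 2-chloro-5-methylphenyl in place of 3-chloro-4-fluorophenyl on a sulfonamide nitrogen. Within the data shown here, the single measured step that bears on this change, a 1.7-fold lower number from compound 1 to compound 2 (0.22 log units; within the scatter), also exchanged the aryl group on the sulfonamide nitrogen and stayed within the scatter. Nothing seen so far shows that such an exchange at this position moves the number beyond the scatter, so no step beyond the scatter in this assay is expected here either. The estimate for compound 3 is 350 nM, with a range from 150 nM to 800 nM. The step of a 1.3-fold higher number from compound 2 to compound 3 (0.13 log units; within the scatter) is the expected consequence.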

Compound 3, concentration for 50% growth inhibition: 48.8 nM
Beside the measured number, compound 3's estimate is 7.2-fold (0.86 log units) above it; the whole stated range lies above it.
By their numbers in this assay, from the lowest: compound 3; then compounds 2 and 1 (each within the scatter of the next).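

In this assay the aryl group on the sulfonamide nitrogen can move the number beyond the scatter (a 5.3-fold lower number from compound 2 to compound 3 (0.73 log units; beyond the scatter)), which the earlier exchange at this place did not do. Within the data shown here, the cleaner reading comes from the second step (an 8.8-fold lower number from compound 1 to compound 3 (0.94 log units; beyond the scatter)), where the only change is methyl in place of hydrogen on an aromatic carbon, so this single group separates 2-chlorophenyl from 2-chloro-5-methylphenyl. No measurement given here accounts for either step.

Open, from the compounds shown here alone, is whether ethyl, methoxy or an amine in place of that methyl would keep the number of compound 3. Also open, going by these compounds, is whether the chlorine of the 2-chloro-5-methylphenyl group is needed for the step at all.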